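Moving a chlorine on the dichlorophenyl group

The source may report more compounds than this note shows. Statements on the series, on what has been measured and on what is new or still open speak of the compounds shown alone.

In an ADME assay on MT4 cells (Homo sapiens) for cytotoxicity, read by MTT assay (a lower number here means that less compound is tolerated, a higher number that more compound is tolerated), compound 3 (`Cc1ccc(N(C(=O)c2ccc(Cl)cc2Cl)C(=S)OCCN2C(=O)c3ccccc3C2=O)cc1`) gives 49000 nM as its half-maximal cytotoxic concentration. Compound 2 (`O=C1c2ccccc2C(=O)N1CCOC(=S)N(C(=O)c1ccc(Cl)c(Cl)c1)c1ccc(Cl)cc1`) gives 35000 nM on the same measure, and the two values lie within the scatter of each other. For compound 1 (`Cc1ccc(N(C(=O)c2cccc(C)c2)C(=S)OCCN2C(=O)c3ccccc3C2=O)cc1`) the reading > 100000 nM is a limit and not a number.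

Compound 4 (`Cc1ccc(N(C(=O)c2ccc(Cl)c(Cl)c2)C(=S)OCCN2C(=O)c3ccccc3C2=O)cc1`) has not yet been measured. Against compound 3 it carries 3,4-dichlorophenyl in place of 2,4-dichlorophenyl on a carbonyl carbon with the same atoms joined differently.

Among the measured compounds shown here, only one measured step touches this place. It is an at least 2.0-fold lower number from compound 1 to compound 3 (0.30 log units; that floor lies within the scatter) when 2,4-dichlorophenyl replaces 3-methylphenyl there, and its floor lies within the scatter. For the measured compounds named here, no measured step isolates the move from 2,4-dichlorophenyl to 3,4-dichlorophenyl. Compound 2 also carries 3,4-dichlorophenyl, though the rest of its structure is not the same, and its value of 35000 nM sits within the scatter of compound 3. No change beyond the scatter is therefore expected in this assay for this swap. The estimated move is a 1.2-fold lower number from compound 3 to compound 4 (0.07 log units; within the scatter) and it stays within the scatter. Compound 4 is expected at 42000 nM with an estimated range of 20000 nM to 90000 nM on this measure.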

Compound 4, half-maximal cytotoxic concentration: 17000 nM
The estimate for compound 4 lay 2.5-fold (0.39 log units) above the measured number; the measured number lies below the stated range.
By their numbers in this assay, from the lowest: compound 4; then compounds 2 and 3 (each within the scatter of the next). At a limit, above all of these: compound 1.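

In this assay, among the compounds shown here, the arrangement of the two chlorines on the phenyl group at this carbonyl carbon turns out to matter, with the same atoms joined differently giving a 2.9-fold lower number from compound 3 to compound 4 (0.46 log units; beyond the scatter), a modest change but one beyond the scatter that the earlier compounds could not isolate. With 3,4-dichlorophenyl held constant, methyl in place of chloro on an aromatic carbon gives a 2.1-fold lower number from compound 2 to compound 4 (0.31 log units; beyond the scatter), which is also modest and beyond the scatter. Swapping 3-methylphenyl for 3,4-dichlorophenyl gives an at least 5.8-fold lower number from compound 1 to compound 4 (0.76 log units; beyond the scatter), and this step is only a floor, as compound 1 stands at a limit: the limit of > 100000 nM in this assay, at which 1 of the 4 values shown sits.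

The compounds shown leave open whether the difference between 3,4-dichlorophenyl and 2,4-dichlorophenyl would hold with chloro in place of methyl on that aromatic carbon, as compound 2 has no partner carrying 2,4-dichlorophenyl among them. They also leave open how a phenyl group bearing a single chlorine, or a methoxy group, on this carbonyl carbon would read in this assay.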